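The source may report more compounds than this note shows. Statements on the series, on what has been measured and on what is new or still open speak of the compounds shown alone.

Measured compounds in an assay on isolated protein for inhibition of serine/threonine-protein kinase PLK1 (Homo sapiens), read by Z'-LYTE; a higher number here means a weaker inhibitor, a lower number a stronger inhibitor: compound 1 `COc1cc(C(=O)NC2CCN(C)CC2)ccc1Nc1ncc2c(n1)N(C1CCCC1)[C@H](C)C(=O)N2C` gives 1.1 nM; compound 2 `COc1cc(C(=O)NC2CCN(C)CC2)ccc1Nc1ncc2c(n1)N(C1CCCC1)[C@@H](C)C(=O)N2C` gives 8.7 nM; compound 3 `COc1cc(C(=O)NC2=CCN(C)C=C2)ccc1Nc1ncc2c(n1)N(C1CCCC1)[C@H](C)C(=O)N2C` gives 8.4 nM.

Compound 3 stands second highest of the three numbers, within the scatter of compound 2 and well above compound 1. Compound 4 `COc1cc(C(=O)N2CCCCC2)ccc1Nc1ncc2c(n1)N(C1CCCC1)[C@H](C)C(=O)N2C` differs from compound 3 by a group of 6 heavy atoms (5 carbon, 1 nitrogen; one six-membered non-aromatic ring with 1 hetero atom) in place of a group of 8 heavy atoms (6 carbon, 2 nitrogen; one six-membered non-aromatic ring with 1 hetero atom), on a carbonyl carbon. Of the measured steps only the change of the amide substituent bears on this: a 7.6-fold higher number from compound 1 to compound 3 (0.88 log units; beyond the scatter). The stereochemical step a 7.9-fold higher number from compound 1 to compound 2 (0.90 log units; beyond the scatter) rests on the fact that compounds 1 and 2 differ only in the configuration as drawn and says nothing about the amide position. The prior amide swap cost potency, and the present swap is a larger change at the same carbonyl, so a further weakening is expected in this assay, about a 4.8-fold higher number from compound 3 to compound 4 (0.68 log units; beyond the scatter). For compound 4 the expected value is 40 nM, within 8 nM to 200 nM.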

Compound 4, half-maximal inhibitory concentration: 95 nM
Compound 4: middle estimate off by 2.4-fold (0.38 log units), on the low side; measured number inside the range.
By their numbers in this assay, from the lowest: compound 1; then compounds 3 and 2 (each within the scatter of the next); then compound 4.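

In this assay, piperidin-1-yl in place of (1-methylpiperidin-4-yl)amino on the carbonyl carbon gives an 86-fold higher number from compound 1 to compound 4 (1.94 log units; beyond the scatter), a large step, beyond the modest 7.6-fold higher number from compound 1 to compound 3 (0.88 log units; beyond the scatter) seen earlier at this position. Compound 3 offers no buffer against this loss, with an 11-fold higher number from compound 3 to compound 4 (1.05 log units; beyond the scatter). No available evidence bears on the reason for this loss.

Still open, going by these compounds, is whether the amide hydrogen or the ring nitrogen matters more. Cyclohexylamino on the same carbonyl carbon would keep only the first, and a methylpiperazine amide only the second.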